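A few compounds are considered here, and "the series" means these few. Any claim that something is new, unique, unknown or untested is made for them only; others in the source may bear on it.

Measured so far: compound 1 `COc1ccc2cc([C@H](C)c3nnc(SCc4ccc(C)cc4)n3-c3ccc(Cl)cc3)ccc2c1`, compound 2 `COc1ccc2cc([C@H](C)c3nnc(SCc4ccc(Cl)cc4)n3-c3ccc(F)cc3)ccc2c1` and compound 3 `COc1ccc2cc([C@H](C)c3nnc(SCc4c(Cl)cccc4Cl)n3-c3ccc(F)cc3)ccc2c1`. In a functional assay on DU-145 cells (Homo sapiens) for cytotoxicity, read by MTT assay (a lower number here means a stronger inhibitor, a higher number a weaker inhibitor), compound 1 gives 18800 nM, compound 2 gives 57400 nM and compound 3 gives 12300 nM.

For the measured compounds named here, compound 3 has the lowest number of the three, close to compound 1 and clearly apart from compound 2; the only single-point step known is a 4.7-fold lower number from compound 2 to compound 3 (0.67 log units; beyond the scatter). Compound 4 `COc1ccc2cc([C@H](C)c3nnc(SCc4c(Cl)cccc4Cl)n3-c3ccc(Cl)cc3)ccc2c1` differs from compound 3 in one place: chloro in place of fluoro on an aromatic carbon. Going by the values given here, no measured step isolates this change. Compounds 1 and 2 differ in two places, so their values show only that the one carrying chloro rather than fluoro at the changed place gives the lower number. The change is therefore expected to bring a 1.4-fold lower number from compound 3 to compound 4 (0.14 log units; within the scatter), a step that stays within the scatter. Compound 4 is expected to give 9000 nM, within 3500 nM to 25000 nM.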

Compound 4, half-maximal inhibitory concentration: 36100 nM
The estimate for compound 4 lay 4.0-fold (0.60 log units) below the measured number; the measured number lies above the stated range.
By their numbers in this assay, from the lowest: compounds 3, 1, 4 and 2 (each within the scatter of the next, the first and the last beyond it).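

In this assay, the change from 4-fluorophenyl to 4-chlorophenyl, now isolated in a single step, gives a 2.9-fold higher number from compound 3 to compound 4 (0.47 log units; beyond the scatter), so with the 2,6-dichlorophenyl group held fixed, fluoro at this aromatic carbon goes with the lower number. With chloro held fixed, 2,6-dichlorophenyl in place of 4-methylphenyl gives a 1.9-fold higher number from compound 1 to compound 4 (0.28 log units; within the scatter), so that swap shows no clear difference here. No measured evidence explains either result. From the compounds shown here alone, whether an amine at this aromatic carbon would give a lower or higher number stays open, as does whether fluoro keeps its advantage with other groups on the chain carbon bound to sulfur.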